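This account rests on a few compounds, and the source may have more. Where it says the series, first, only, none or still open, it means among the compounds named here.

The account follows a single change made to compound 2, whose structure is `Cc1cc(NCc2cnccn2)n2nc(C)c(-c3ccccc3)c2n1`. Among the measured compounds shown here, in a physicochemical assay for solubility, read by HPLC, using the shake flask method, measured as kinetic solubility, with a stated time of 2 h, at pH 7.4 (on this read-out higher numbers stand for higher solubility and lower numbers for lower solubility), compound 2 gives 7100 nM, and among the two results in hand this is the only one reported as a number. Compound 1, with structure `Cc1ccc(-c2cnn3c(NCc4ccccn4)cc(C)nc23)cc1`, gives in this assay a result of < 5000 nM, which is a limit of the assay and not a number. That result of compound 1 sits at the limit of < 5000 nM in this assay, at which 1 of the 2 values shown sits. For the measured compounds named here, no step between two measured compounds is available, so nothing measured yet shows how this kind of change moves solubility. Compound 3, whose structure is `Cc1cc(NCC2CCCCN2)n2nc(C)c(-c3ccccc3)c2n1`, has not yet been measured in this assay. It differs from compound 2 in one place: piperidin-2-yl in place of pyrazin-2-yl on a saturated chain carbon bound to a nitrogen on an aromatic ring. For this change an increase in solubility is expected, and the expected step of a 4.9-fold higher number from compound 2 to compound 3 (0.69 log units; beyond the scatter) is anticipated to lie beyond the usual scatter of repeated measurements. Compound 3 is accordingly estimated at 35000 nM, with an expected range from 9000 nM to 150000 nM.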

Compound 3, solubility: 189000 nM
Estimate against measurement, compound 3: 5.4-fold (0.73 log units) below; measured number above the stated range.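

In this assay, piperidin-2-yl in place of pyrazin-2-yl on a saturated chain carbon bound to a nitrogen on an aromatic ring gives a 27-fold higher number from compound 2 to compound 3 (1.43 log units; beyond the scatter), the first step measured among these compounds and a large one. It shows that this place is not silent in the read-out: with the rest of compound 2 left as it stands, exchanging one six-membered ring for another moves the number by far more than repeated measurements would. No measurement shown here accounts for the size of this step.

The change from compound 2 to compound 3 alters several things at once, as a six-membered aromatic ring with two hetero atoms gives way to a non-aromatic one with a single hetero atom that carries a hydrogen-bond donor, and the compounds shown do not separate these differences. Also open, from the compounds shown here alone, is whether a morpholin-2-yl ring or an open-chain amine in the same place would give a step of similar size, and whether the step would hold with a different group on the rest of the molecule.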